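The source may report more compounds than this note shows. Statements on the series, on what has been measured and on what is new or still open speak of the compounds shown alone.

The measured compounds:
compound 1, `COc1ccc(-c2cc(=O)c3c(OC)cc(OC)cc3n2C)cc1` — 68000 nM
compound 2, `COC(=O)c1cc(=O)c2cc(NC(=O)Nc3ccc(Cl)c(C(F)(F)F)c3)ccc2[nH]1` — > 12600 nM

In an ADME assay on BJ cells (Homo sapiens) for antiproliferative activity, with a stated time of 72 h (a higher number here means that more compound is needed for the effect, a lower number that less compound is needed), compound 1 gives 68000 nM. In this assay compound 2 gives > 12600 nM, which is a limit of the assay and not a number. Compound 2 therefore stands at the weak end of what this assay can report; its reading is the limit of > 12600 nM in this assay, at which 1 of the 2 values shown sits. For the measured compounds named here, compound 1, by contrast, has a number, and no step between the two is given.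

Compound 3, `COC(=O)c1cc(=O)c2cc(NC(=O)Nc3ccc(Cl)c(Cl)c3)ccc2[nH]1`, has not yet been measured. It differs from compound 2 in one place: chloro in place of trifluoromethyl on an aromatic carbon. No measured step of this kind exists among the compounds shown, so there is nothing to set a size by. Since compound 2 itself is known only as a limit, the starting point is uncertain, and a change of this kind is expected to produce no step beyond the scatter. From compound 2 to compound 3 the expected step in this assay is a step that the limit leaves unreadable from compound 2 to compound 3. Compound 3 is estimated at 20000 nM in this assay, with a range from 8000 nM to 60000 nM, and it is quite likely that this assay again reports only a limit for compound 3.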

Compound 3, half-maximal effective concentration: > 12600 nM
Compound 3: a limit, no number; the forecaster's own chance of this, stated with the estimate: 65%; the middle value lies beyond the limit too.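

In this assay compound 3 gives > 12600 nM as a limit of the assay and not a number. Compound 2 gives > 12600 nM as a limit too, so no step can be read between compound 2 and compound 3. The compounds shown leave open how far each lies beyond its limit and how much chloro in place of trifluoromethyl changes the reading.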